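A few compounds are considered here, and "the series" means these few. Any claim that something is new, unique, unknown or untested is made for them only; others in the source may bear on it.

Working notes on the series in an ADME assay on Vero cells (Chlorocebus sabaeus) for cytotoxicity, read by MTT assay; a higher number here means a weaker inhibitor, a lower number a stronger inhibitor. Compound 1 `C=CCOc1cc(OC)c(C(=O)/C=C/c2ccc(F)cc2)c(OCC=C)c1` gives 13600 nM, compound 2 `C=CCOc1cc(OC)c(C(=O)/C=C/c2ccccc2)c(OCC=C)c1` gives 17100 nM and compound 3 `C=CCOc1cc(OC)c(C(=O)/C=C/c2ccccc2F)c(OCC=C)c1` gives 16300 nM. Compound 3 therefore stands within the scatter of both others, as shown by a 1.0-fold lower number from compound 2 to compound 3 (0.02 log units; within the scatter) and a 1.2-fold higher number from compound 1 to compound 3 (0.08 log units; within the scatter). The remaining measured step, a 1.3-fold higher number from compound 1 to compound 2 (0.10 log units; within the scatter), is also within the scatter.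

Compound 4 `C=CCOc1cc(OC)c(C(=O)/C=C/c2ccc([N+](=O)[O-])cc2)c(OCC=C)c1` differs from compound 3 as follows: 4-nitrophenyl in place of 2-fluorophenyl on a double-bonded chain carbon bound to a double-bonded chain carbon. This places 4-nitrophenyl in place of 2-fluorophenyl on a double-bonded chain carbon bound to a double-bonded chain carbon. The closest measured precedent is a 1.2-fold higher number from compound 1 to compound 3 (0.08 log units; within the scatter), which also exchanges one phenyl group for another at that place. Going by the values given here, the steps involving compound 2 bear on the same group, but no measured compound carries 4-nitrophenyl, so the evidence is limited and the range is kept wide. No shift beyond the scatter is expected, and the estimated change is a 1.2-fold lower number from compound 3 to compound 4 (0.07 log units; within the scatter). For compound 4 the expected value is 14000 nM, with an estimated range from 7000 nM to 28000 nM.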

Compound 4, half-maximal inhibitory concentration: 12600 nM
Compound 4: the middle estimate sits 1.1-fold (0.05 log units) above what was measured; low and high end bracket the measured number.
By their numbers in this assay, from the lowest: compounds 4, 1, 3 and 2 (each within the scatter of the next).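

In this assay, 4-nitrophenyl on a double-bonded chain carbon bound to a double-bonded chain carbon stays within the scatter of 2-fluorophenyl (a 1.3-fold lower number from compound 3 to compound 4 (0.11 log units; within the scatter)), and the same holds for nitro in place of hydrogen (a 1.4-fold lower number from compound 2 to compound 4 (0.13 log units; within the scatter)) and nitro in place of fluoro (a 1.1-fold lower number from compound 1 to compound 4 (0.03 log units; within the scatter)). The earlier compounds shown here covered only hydrogen and fluoro on this phenyl group, whereas these steps show that the read-out also fails to separate nitro from either of them. Nothing available accounts for this result.

Going by these compounds, whether an amine or a carboxylic acid on this phenyl group would move the number beyond the scatter remains open. Nitro appears here only as 4-nitrophenyl, so any dependence on where the nitro group sits on the phenyl group also remains open.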